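The source may hold more compounds than are shown below. What is called first, only, known or untested is meant among the compounds shown, and "the series" means these compounds.

Three compounds have been measured in a functional assay on HEK293 cells for antagonist activity at proteinase-activated receptor 4 (Homo sapiens), read by FLIPR and calcium flux, with a stated time of 30 min; on this read-out lower numbers stand for stronger inhibition and higher numbers for weaker inhibition:
compound 1 `COc1cc(OCc2csc(-c3ccc(C(F)(F)F)cc3)n2)c2cc(-c3cn4nc(OC)sc4n3)oc2c1` with 1.3 nM,
compound 2 `CNC(=O)c1ccc(-c2nc(COc3cc(OC)cc4oc(-c5cn6nc(OC)sc6n5)cc34)cs2)cc1` with 0.4 nM,
compound 3 `COc1cc(OCc2csc(-c3ccc(S(C)(=O)=O)cc3)n2)c2cc(-c3cn4nc(OC)sc4n3)oc2c1` with 0.8 nM.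

Compound 1 gives the highest of these three numbers. Its nearest neighbour is compound 3, reached by a 1.6-fold lower number from compound 1 to compound 3 (0.21 log units; within the scatter), a step that stays within the usual scatter of repeated measurements. The furthest is compound 2: a 3.3-fold lower number from compound 1 to compound 2 (0.51 log units; beyond the scatter), a modest step that lies beyond the scatter. Between the other two, a 2.0-fold higher number from compound 2 to compound 3 (0.30 log units; within the scatter) again stays within the scatter.

Compound 4 `COc1cc(OCc2csc(-c3ccc(C(=O)O)cc3)n2)c2cc(-c3cn4nc(OC)sc4n3)oc2c1` has not yet been measured. It differs from compound 1 in one place: carboxy in place of trifluoromethyl on an aromatic carbon. The carboxy enters where the trifluoromethyl leaves, para to a large group.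

Within the data shown here, two measured steps bear on this change. Each of them also replaced trifluoromethyl on that same aromatic carbon: a 3.3-fold lower number from compound 1 to compound 2 (0.51 log units; beyond the scatter) and a 1.6-fold lower number from compound 1 to compound 3 (0.21 log units; within the scatter). One was modest and beyond the scatter, the other within it; neither raised the number. A carboxy is a third such replacement, so the expected step in this assay is a 1.4-fold lower number from compound 1 to compound 4 (0.16 log units; within the scatter), small and downward, or none beyond the scatter. Compound 4 is therefore estimated at 0.9 nM, with a range from 0.3 nM to 2.5 nM.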

Compound 4, half-maximal inhibitory concentration: 1.1 nM
Estimate against measurement, compound 4: 1.2-fold (0.09 log units) below, within the range that was stated.
By their numbers in this assay, from the lowest: compounds 2, 3, 4 and 1 (each within the scatter of the next, the first and the last beyond it).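

In this assay, carboxy, which unlike trifluoromethyl carries a hydrogen-bond donor, cannot be told apart from trifluoromethyl on this aromatic carbon (a 1.2-fold lower number from compound 1 to compound 4 (0.07 log units; within the scatter)). It also cannot be told apart from methylsulfonyl (a 1.4-fold higher number from compound 3 to compound 4 (0.14 log units; within the scatter)), so a third replacement at this position, here with a group that differs from the other two, again gives no step beyond the scatter against compound 1 or compound 3. The new contrast lies within the carbonyl pair: hydroxy in place of methylamino on the carbonyl carbon gives a modest step beyond the scatter (a 2.8-fold higher number from compound 2 to compound 4 (0.44 log units; beyond the scatter)), so at this position the group attached to the carbonyl can be told apart even though carboxy as a whole matches trifluoromethyl and methylsulfonyl.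

No measurement shown explains why these groups give such close numbers or why methylcarbamoyl separates from carboxy. Still open, going by these compounds, is whether a primary amide, a methyl ester, an amine or a plain hydrogen on this carbon would fall in the same narrow band, or would give the first step upward from compound 1.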